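The compounds below may be only part of what the source reports. "The series", "measured", "known", "first", "only" and "open" are said of these compounds alone.

Measured so far:
- Compound 1 `COc1cc(/C(=N\OC(C)=O)c2ccc3c(ccn3C)c2)cc(OC)c1OC`: in a functional assay on HL-60 cells (Homo sapiens) for cytotoxicity, read by XTT assay, with a stated time of 72 h (a lower number here means a stronger inhibitor, a higher number a weaker inhibitor), compound 1 gives > 10000 nM, which is a limit of the assay and not a number.
- Compound 2 `COc1cc(/C(=N/C(=O)OC(C)(C)C)c2ccc3c(ccn3C)c2)cc(OC)c1OC`: in this assay compound 2 gives > 1000 nM, again a limit and not a number.

Compound 2 therefore stands only at a limit. Its result sits at the limit of > 1000 nM in this assay, at which 1 of the 2 values shown sits. The result of compound 1 sits at the limit of > 10000 nM in this assay, at which 1 of the 2 values shown sits. Among the compounds with values here, neither value is an exact figure, so the two compounds cannot be ordered against each other, and no measured step exists between them.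

Compound 3 `COc1cc(/C(=N\C(=O)OC(C)(C)C)c2ccc3c(ccn3C)c2)cc(OC)c1OC` is the next compound. Against compound 2 the difference is small on paper: the two compounds have the same atoms and bonds and differ only in configuration as drawn: 1 of 1 stereo elements differ; a double bond is drawn E in compound 2 and Z in compound 3. Within the data shown here, nothing among the measured compounds shows how such a change of drawn configuration at the double bond moves potency in this assay, so no direction can be read from the data. The expectation is a step of no more than the usual scatter, and most likely a result that is again reported only as a limit.

Compound 3 is therefore estimated at 5000 nM, within 800 nM to 30000 nM, which corresponds to an expected step that the limit leaves unreadable from compound 2 to compound 3.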

Compound 3, half-maximal inhibitory concentration: > 1000 nM
Compound 3: only a limit was reported; the forecaster's own chance of this, stated with the estimate: 70%; the middle value lies beyond the limit too.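

In this assay compound 3 gives > 1000 nM, a limit of the assay and not a number, and no step can be read between it and compound 1 or compound 2, whose results are also limits. Still open, as far as these compounds go, is whether changing the drawn double-bond configuration, or exchanging acetoxy for tert-butoxycarbonyl, shifts potency at all.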